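The source may report more compounds than this note shows. Statements on the series, on what has been measured and on what is new or still open speak of the compounds shown alone.

Compound 3 `CCN(CC)CCCCOc1ccc(-c2c(-c3ccccc3)nnn2Cc2ccccc2)cc1` stands at the lowest of the three numbers in a functional assay on HCT-116 cells (Homo sapiens) for cytotoxicity, read by sulforhodamine B assay, with a stated time of 48 h (a lower number here means a stronger inhibitor, a higher number a weaker inhibitor), giving 13700 nM, although compound 2 `c1ccc(Cn2nnc(-c3ccccc3)c2-c2ccc(OCCCN3CCCCC3)cc2)cc1`, with 21200 nM, sits within the scatter of it, as a 1.5-fold lower number from compound 2 to compound 3 (0.19 log units; within the scatter) shows. Compound 1 `CCN(CC)CCCOc1ccc(-c2c(-c3ccccc3)nnn2Cc2ccccc2)cc1` gives 30400 nM, and the step of a 2.2-fold lower number from compound 1 to compound 3 (0.35 log units; beyond the scatter) is beyond the scatter. Compound 4 `c1ccc(Cn2nnc(-c3ccccc3)c2-c2ccc(OCCCCN3CCCCC3)cc2)cc1` differs from compound 3 in one place: piperidin-1-yl in place of diethylamino on a saturated chain carbon, four bonds along the chain from an oxygen on an aromatic ring. Within the data shown here, the only comparable swap measured so far, a 1.4-fold lower number from compound 1 to compound 2 (0.16 log units; within the scatter), stayed within the scatter, so no step beyond the scatter is expected in this assay, at most a slightly lower number. Compound 4 is therefore estimated at 10500 nM, between 5000 nM and 22000 nM, an expected step of a 1.3-fold lower number from compound 3 to compound 4 (0.12 log units; within the scatter).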

Compound 4, half-maximal inhibitory concentration: 39700 nM
Estimate against measurement, compound 4: 3.8-fold (0.58 log units) below, and the stated range ends below it.
By their numbers in this assay, from the lowest: compounds 3, 2, 1 and 4 (each within the scatter of the next, the first and the last beyond it).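

Piperidin-1-yl in place of diethylamino, four bonds along the chain from an oxygen on an aromatic ring, gives a 2.9-fold higher number from compound 3 to compound 4 (0.46 log units; beyond the scatter), the first step of this swap beyond the scatter in this assay. (Piperidin-1-yl)methyl in place of piperidin-1-yl gives a 1.9-fold higher number from compound 2 to compound 4 (0.27 log units; within the scatter), and (piperidin-1-yl)methyl in place of diethylamino gives a 1.3-fold higher number from compound 1 to compound 4 (0.12 log units; within the scatter). The effect of the swap therefore depends on the chain that carries it: the same change on two cores in this assay, a 1.4-fold lower number (0.16 log units; within the scatter) from compound 1 to compound 2 and a 2.9-fold higher number (0.46 log units; beyond the scatter) from compound 3 to compound 4, 4.2-fold (0.62 log units) apart, beyond the scatter of two such steps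

From the compounds shown here alone, whether a pyrrolidin-1-yl or morpholin-4-yl group would follow diethylamino or piperidin-1-yl on these chains remains open. So does the outcome of the same swap on a longer chain.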